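Methyl for trifluoromethyl on the amide aryl group

The source may report more compounds than this note shows. Statements on the series, on what has been measured and on what is new or still open speak of the compounds shown alone.

In an assay on CHO cells with metabotropic glutamate receptor 5 (Homo sapiens) as the target (a lower number here means that less compound is needed, a higher number that more compound is needed for the effect), compound 3 `O=C(Nc1cc(-c2ccccc2)nn1-c1ccccc1)c1ccc(C(F)(F)F)cc1` gives 19 nM, the lowest of the numbers shown. Compound 1 `O=C(Nc1cc(-c2ccccc2)nn1-c1ccccc1)c1ccccc1Cl` gives 2500 nM in this assay. In this assay compound 2 `Cc1ccccc1C(=O)Nc1cc(-c2ccccc2)nn1-c1ccccc1` gives only > 10000 nM, a limit of the assay rather than a number. Between these three, an at least 4.0-fold higher number from compound 1 to compound 2 (0.60 log units; beyond the scatter), a 130-fold lower number from compound 1 to compound 3 (2.12 log units; beyond the scatter) and an at least 520-fold lower number from compound 2 to compound 3 (2.72 log units; beyond the scatter). Compound 4 `Cc1cccc(C(=O)Nc2cc(-c3ccccc3)nn2-c2ccccc2)c1` carries 3-methylphenyl in place of 4-(trifluoromethyl)phenyl on a carbonyl carbon. Both large steps that arrive at compound 3 replaced a differently substituted phenyl group with the 4-(trifluoromethyl)phenyl group, and the change to compound 4 removes that group again, so a clear rise in the number is expected: a 21-fold higher number from compound 3 to compound 4 (1.32 log units; beyond the scatter). Compound 4 is therefore estimated at 400 nM, with a range from 60 nM to 4000 nM.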

Compound 4, half-maximal effective concentration: 90 nM
The estimate for compound 4 lay 4.4-fold (0.65 log units) above the measured number; the range from low to high includes it.
By their numbers in this assay, from the lowest: compound 3; then compound 4; then compound 1. At a limit, above all of these: compound 2.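

Trifluoromethyl is not needed for a low number here: the change to 3-methylphenyl brings only a modest step, a 4.7-fold higher number from compound 3 to compound 4 (0.68 log units; beyond the scatter). Moving the methyl group from 2-methylphenyl to 3-methylphenyl gives an at least 110-fold lower number from compound 2 to compound 4 (2.04 log units; beyond the scatter), and 3-methylphenyl in place of 2-chlorophenyl gives a 28-fold lower number from compound 1 to compound 4 (1.44 log units; beyond the scatter), so among these compounds the place of the group on the ring matters. The first of these two steps starts from a limit of the assay, not a number: the limit of > 10000 nM in this assay, at which 1 of the 4 values shown sits.

Going by these compounds, compound 3 and compound 4 differ in both the group and its place, so the share of each in their step stays open. Also open, on these data alone, is how an amine or a carboxylic acid on this ring would behave.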